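Methyl to Methoxy on the Benzyl Ring of Compound 3

The compounds below may be only part of what the source reports. "The series", "measured", "known", "first", "only" and "open" are said of these compounds alone.

Compound 1 `O=C(/C=C/c1coc2cc(O)ccc2c1=O)NCc1ccccc1`: > 100000 nM
Compound 2 `COc1ccc(CNC(=O)/C=C/c2coc3cc(OC)ccc3c2=O)cc1`: 22500 nM
Compound 3 `Cc1ccc(CNC(=O)/C=C/c2coc3cc(O)ccc3c2=O)cc1`: 17400 nM

In a functional assay on A549 cells (Homo sapiens) for inhibition, read by MTT assay, with a stated time of 48 h (a higher number here means a weaker inhibitor, a lower number a stronger inhibitor), compound 3 gives 17400 nM, the lowest of the two numbers reported. Compound 2 gives 22500 nM, which lies within the scatter of the number for compound 3. For compound 1 this assay reports only a limit, > 100000 nM (the limit of > 100000 nM in this assay, at which 1 of the 3 values shown sits). Among the measured compounds shown here, the one step that can be read from these three is an at least 5.7-fold lower number from compound 1 to compound 3 (0.75 log units; beyond the scatter).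

Compound 4 `COc1ccc(CNC(=O)/C=C/c2coc3cc(O)ccc3c2=O)cc1` differs from compound 3 by methoxy in place of methyl on an aromatic carbon. For the measured compounds named here, no measured step covers this exchange directly: the single step known concerns a methyl entering where hydrogen stood, not methyl giving way to methoxy. Compound 2 also carries a methoxy on that ring but differs from compound 4 at a second position as well, so its value is only a loose guide; it sits within the scatter of compound 3. The step is therefore expected to be a 1.1-fold higher number from compound 3 to compound 4 (0.06 log units; within the scatter), no change beyond the scatter. Compound 4 is estimated at 20000 nM, with a range from 8000 nM to 50000 nM.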

Compound 4, half-maximal inhibitory concentration: > 100000 nM
Compound 4: a limit, no number; the forecaster's own chance of this, stated with the estimate: 10%; at least 5.0-fold (0.69 log units) between middle value and limit.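

In this assay, the change from 4-methylphenyl to 4-methoxyphenyl is not a silent exchange: it gives an at least 5.7-fold higher number from compound 3 to compound 4 (0.75 log units; beyond the scatter). The methoxy group alone does not fix this outcome, since with it held in place, hydrogen in place of methyl on an oxygen on an aromatic ring gives an at least 4.4-fold higher number from compound 2 to compound 4 (0.64 log units; beyond the scatter), and compound 2 therefore goes against any reading that ties the result to methoxy on this ring by itself. Compound 4 gives only a limit, and the step between compound 1 and compound 4 cannot be read: the limit of > 100000 nM in this assay, at which 2 of the 4 values shown sit.

What the compounds shown leave open is how far compound 4 lies past that limit. They also leave open whether an amine, a chlorine atom or a longer ether chain at this place would pair with the free hydroxyl of compound 3 as methoxy does, or keep a readable number.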